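Benzyl Swap on a Trimethoxyphenyl Amide, Before Measurement

The source may hold more compounds than are shown below. What is called first, only, known or untested is meant among the compounds shown, and "the series" means these compounds.

Compound 1 `COc1ccc(CN(C(=O)CSc2nc3ccccc3s2)c2cc(OC)c(OC)c(OC)c2)cc1O` gives 182 nM in a functional assay on HCT-116 cells (Homo sapiens) for antiproliferative activity, read by MTT assay, with a stated time of 48 h (on this read-out higher numbers stand for weaker inhibition and lower numbers for stronger inhibition), the lowest of the two numbers measured; compound 2 `COc1ccc(CN(C(=O)CSc2nc3cc(Br)ccc3s2)c2cc(OC)c(OC)c(OC)c2)cc1O` gives 3380 nM, and a 19-fold higher number from compound 1 to compound 2 (1.27 log units; beyond the scatter). Compound 3 `COc1cc(N(Cc2ccc(Br)cc2)C(=O)CSc2nc3ccccc3s2)cc(OC)c1OC` differs from compound 1 by 4-bromophenyl in place of 3-hydroxy-4-methoxyphenyl on a saturated chain carbon bound to an amide-type nitrogen. For the measured compounds named here, no measured step touches this group; the only known step concerns a bromo on an aromatic carbon of the shared core, not the benzyl group, so it shows merely that one change here can move the number well beyond the scatter. Compound 3 is therefore expected to give a weaker and uncertain 900 nM, between 200 nM and 4000 nM, a step of a 4.9-fold higher number from compound 1 to compound 3 (0.69 log units; beyond the scatter).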

Compound 3, half-maximal inhibitory concentration: 63800 nM
Beside the measured number, compound 3's estimate is 71-fold (1.85 log units) below it, outside the stated range (above it).
By their numbers in this assay, from the lowest: compound 1; then compound 2; then compound 3.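

In this assay the change from 3-hydroxy-4-methoxybenzyl to 4-bromobenzyl gives a 350-fold higher number from compound 1 to compound 3 (2.54 log units; beyond the scatter) and so shows that the benzyl position, untouched by the earlier step on the shared core, strongly affects the number. The hydrogen-bond donor and acceptors of the old group leave as the bromine enters, and this single step cannot separate those changes. No available evidence explains the size of this step. The compounds shown leave open whether a plain benzyl or a 3-hydroxybenzyl group at this place would keep the number of compound 1.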